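This account rests on a few compounds, and the source may have more. Where it says the series, first, only, none or still open, it means among the compounds named here.

Compound 1, `CCC1(CCCCN2CCN(c3ccc(Cl)cc3)CC2)C(=O)Nc2ccccc21`, gives > 10 mg/kg in a functional assay on the whole organism (strain NMRI) with Mus musculus as the target, with a stated time of 5 min (a higher number here means that more compound is needed for the effect, a lower number that less compound is needed), which is a limit of the assay and not a number.
Compound 2, `CC(C)CC1(CCCCN2CCN(c3cccc(Cl)c3)CC2)C(=O)Nc2ccccc21`, gives > 10 mg/kg in this assay, again only a limit.
Compound 3, `CCC1(CCCCN2CC=C(c3ccc(F)cc3)CC2)C(=O)Nc2ccccc21`, has the entry "not determined" (no result reported) in this assay.

Within the data shown here, compound 2 thus stands at the limit of > 10 mg/kg in this assay, at which 2 of the 3 values shown sit; with only this bound known for it, no measured step leads away from it. Compound 4, `O=C1Nc2ccccc2C1CCCCN1CCN(c2cccc(Cl)c2)CC1`, differs from compound 2 by hydrogen in place of isobutyl on a saturated ring carbon. Among the measured compounds shown here, no measured pair shows this change, so its size cannot be read from the data. The expectation is that compound 4 stays near the same bound in this assay, with no shift beyond the usual scatter. Compound 4 is estimated at 15 mg/kg, in the range 5 mg/kg to 50 mg/kg. The expected step is a step that the limit leaves unreadable from compound 2 to compound 4.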

Compound 4, minimum effective dose: > 10 mg/kg
Compound 4 ended at the assay's limit; the forecaster's own chance of this, stated with the estimate: 70%; the middle value lies beyond the limit too.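

Among these compounds, compound 2 and compound 4 both stand at a limit in this assay, not at a number, so no step between them can be read. The compounds shown leave open whether hydrogen in place of isobutyl changes the dose needed in this assay at all.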